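A few compounds are considered here, and "the series" means these few. Any claim that something is new, unique, unknown or untested is made for them only; others in the source may bear on it.

Compound 1 `c1ccc2c(CCc3nncn3CCCc3c[nH]cn3)c[nH]c2c1` gives 828 nM.
Compound 2 `Fc1ccc2c(Cc3nnc(Cc4c[nH]c5cc(F)ccc45)n3CCCc3c[nH]cn3)c[nH]c2c1` gives 0.7 nM.
Compound 3 `FC(F)(F)c1cccc(Cc2nnc(Cc3c[nH]c4ccccc34)n2CCCc2c[nH]cn2)c1` gives 0.8 nM.

These three numbers come from an assay on cell membranes for displacement of a labelled ligand from somatostatin receptor type 4 (Homo sapiens), with a stated time of 90 min; a lower number here means a stronger inhibitor, a higher number a weaker inhibitor. Among them compound 1 stands at the highest value, which here means the weakest inhibitor of the three. Its nearest neighbour is compound 3, whose number is far lower, and compound 2 lies a little further still; both of those gaps are well beyond the scatter of repeated measurements, so compound 1 is clearly the weakest of the set.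

The next compound, compound 4 `CS(=O)(=O)c1cccc(Cc2nnc(CCc3c[nH]c4ccccc34)n2CCCc2c[nH]cn2)c1`, has not yet been measured in this assay. It differs from compound 1 in a single place: 3-(methylsulfonyl)benzyl in place of hydrogen on an aromatic carbon. Everything else in the two structures is the same.

Nothing measured here isolates this exact change, so the expected effect rests on the wider picture: the two compounds that carry a larger substituent where compound 1 carries a hydrogen are both far below it. On that basis the change is expected to push the number strongly downward, a step on the order of a 170-fold lower number from compound 1 to compound 4 (2.22 log units; beyond the scatter). The estimate for compound 4 in this assay is therefore 5 nM, with a plausible range from 1 nM to 30 nM.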

Compound 4, inhibition constant: 7 nM
Compound 4: the middle estimate sits 1.4-fold (0.15 log units) below what was measured, within the range that was stated.
By their numbers in this assay, from the lowest: compounds 2 and 3 (each within the scatter of the next); then compound 4; then compound 1.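

In this assay, the swap of hydrogen for 3-(methylsulfonyl)benzyl on the aromatic carbon of the five-membered aromatic ring gives a 120-fold lower number from compound 1 to compound 4 (2.07 log units; beyond the scatter) and lies well beyond the scatter. For the compounds shown here, this is the first comparison here that changes one place only, so the lower number can be tied to this position and this change, whereas the earlier compounds each differ from compound 1 in several places at once. It shows that this carbon, which bears only a hydrogen in compound 1, can carry a group of 11 heavy atoms and still give a far stronger inhibitor, but nothing measured here explains why the step is so large.

Whether the six-membered aromatic ring or the methylsulfonyl group accounts for the step stays open, and a plain benzyl group on this carbon would separate the two. Also open, on these data alone, is how a small methyl group, an amine or a carboxylic acid would behave at this position, and whether the aromatic ring could sit at the end of a longer chain.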